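Sulfonyl substituent swap on the acylurea benzothiazole series

The compounds below may be only part of what the source reports. "The series", "measured", "known", "first", "only" and "open" are said of these compounds alone.

Three members of the series have numbers in an assay on HEK293 cells for displacement of a labelled ligand from growth hormone secretagogue receptor type 1 (Homo sapiens), with a stated time of 60 min; on this read-out lower numbers stand for stronger inhibition and higher numbers for weaker inhibition. Compound 2 `CN1CCC(S(=O)(=O)c2ccc3nc(NC(=O)NC(=O)c4cc(N5CCCC5)c(C#N)cc4Cl)sc3c2)CC1` gives 0.4 nM, the lowest of the three. Going by the values given here, compound 1 `CN1CCC(S(=O)(=O)c2ccc3nc(NC(=O)NC(=O)c4cc(N5CCCC5)ccc4Cl)sc3c2)CC1` gives 0.92 nM; the step of a 2.3-fold lower number from compound 1 to compound 2 (0.36 log units; beyond the scatter) is the only single-point change among the measured compounds. Compound 3 `CN(C)CCCS(=O)(=O)c1ccc2nc(NC(=O)NC(=O)c3ccccc3Cl)sc2c1` gives 8.7 nM; it differs from compound 2 in more than one place, so its value shows only that a chain-bearing sulfonyl with a plainer benzoyl group sits well above compound 2.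

Compound 4 `CN1CCN(CCCS(=O)(=O)c2ccc3nc(NC(=O)NC(=O)c4cc(N5CCCC5)c(C#N)cc4Cl)sc3c2)CC1` is not yet measured. It differs from compound 2 by 3-(4-methylpiperazin-1-yl)propyl in place of 1-methylpiperidin-4-yl on a sulfonyl sulfur. Among the compounds with values here, no measured step alters the sulfonyl substituent alone, so the step from compound 1 to compound 2 does not bear on it, and the gap between compound 2 and compound 3 is not attributable to this change by itself. The expectation is therefore a step in this assay of about a 1.8-fold higher number from compound 2 to compound 4 (0.24 log units; within the scatter), close to the scatter, with a slight lean towards a higher number. Compound 4 is expected to give 0.7 nM, with a range from 0.25 nM to 2.5 nM.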

Compound 4, half-maximal inhibitory concentration in the growth hormone secretagogue receptor type 1 assay: 0.24 nM
Compound 4: middle estimate off by 2.9-fold (0.46 log units), on the high side, and the stated range ends above it.
By their numbers in the growth hormone secretagogue receptor type 1 assay, from the lowest: compounds 4 and 2 (each within the scatter of the next); then compound 1; then compound 3.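

In the growth hormone secretagogue receptor type 1 assay the sulfonyl position carries 3-(4-methylpiperazin-1-yl)propyl in place of 1-methylpiperidin-4-yl with no change beyond the scatter (a 1.7-fold lower number from compound 2 to compound 4 (0.22 log units; within the scatter)), so with a larger group with a second ring nitrogen and an open chain on the sulfonyl sulfur compound 4 gives 0.24 nM, level with compound 2 at 0.4 nM. In a physicochemical assay for lipophilicity (a higher number here means a more lipophilic compound, a lower number a more polar compound), the same swap also stays within the scatter (a number 0.20 log units lower from compound 2 to compound 4 (within the scatter)), with compound 2 at 3 and compound 4 at 2.8. No supporting evidence explains either result.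

As far as these compounds go, it remains open whether a longer chain carrying the same 4-methylpiperazin-1-yl group, or a carboxylic acid on the propyl chain, would hold this level. The compounds shown also do not settle whether the new sulfonyl substituent behaves the same way on the core of compound 1, which lacks the nitrile.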